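Replacing naphthalen-1-yl with 2-methoxyphenoxy: expected acidity

This account rests on a few compounds, and the source may have more. Where it says the series, first, only, none or still open, it means among the compounds named here.

Three related compounds have been measured in a physicochemical assay for acid dissociation. Compound 1 `COc1cccc(Oc2ccc3c(NCCCNCc4cc(F)ccc4OC)ccnc3c2)c1` gives 9.28. Compound 2 `COc1ccc(F)cc1CNCCCNc1ccnc2cc(Cc3ccccc3)ccc12` gives 9.47, and compound 3 `COc1ccc(F)cc1CNCCCNc1ccnc2cc(-c3cccc4ccccc34)ccc12` gives 9.47. Compound 3 is level with compound 2 at the digits shown, and together they hold the highest of the three numbers; furthest from compound 3 is compound 1, although even that gap, a number 0.19 log units higher from compound 1 to compound 3 (within the scatter), lies within the scatter. The remaining steps are alike: a number 0.19 log units higher from compound 1 to compound 2 (within the scatter) and no change at the digits printed from compound 2 to compound 3 (within the scatter).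

Compound 4 `COc1ccc(F)cc1CNCCCNc1ccnc2cc(Oc3ccccc3OC)ccc12` has not yet been measured. It differs from compound 3 in one place: 2-methoxyphenoxy in place of naphthalen-1-yl on an aromatic carbon. The measured step that bears most on this, a number 0.19 log units higher from compound 1 to compound 3 (within the scatter), ran the opposite way, with a naphthalen-1-yl taking the place of a 3-methoxyphenoxy group. Every measured step stayed inside the scatter, so no step beyond it in this assay is expected here either. The expected step is a number 0.17 log units lower from compound 3 to compound 4 (within the scatter). Compound 4 is estimated at 9.3, with a range from 9 to 9.6.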

Compound 4, acid dissociation constant: 9.28
For compound 4 the middle estimate is 0.02 log units above the measured one; measured number inside the range.
By their numbers in this assay, from the lowest: compounds 1, 4, 2 and 3 (each within the scatter of the next).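

In this assay, putting 2-methoxyphenoxy where compound 1 carries 3-methoxyphenoxy gives no change at the digits printed from compound 1 to compound 4 (within the scatter), so moving the methoxy group within the phenoxy substituent has no readable effect on this number. Comparison with the groups that lack oxygen points the same way, with a number 0.19 log units lower from compound 3 to compound 4 (within the scatter) when naphthalen-1-yl leaves and a number 0.19 log units lower from compound 2 to compound 4 (within the scatter) when benzyl leaves. All four groups at this aromatic carbon therefore stay within the scatter of one another, and no measurement is at hand to explain these numbers.

The compounds shown leave open whether a group of a different kind at this position, such as an amine or a carboxylic acid, would shift the number beyond the scatter. They also leave open what a longer chain elsewhere in the shared core would do.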